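Solubility notes: carboxymethylamino for cyano on the fused core

The source may hold more compounds than are shown below. What is called first, only, known or untested is meant among the compounds shown, and "the series" means these compounds.

Among the measured compounds shown here, compound 3 `N#Cc1ccc2ccc(C(=O)c3ccc(F)c(O)c3)nc2c1` gives 25000 nM in a physicochemical assay for solubility, in phosphate buffer, with a stated time of 24 h, at pH 7.4, tested at 200 uM (on this read-out lower numbers stand for lower solubility and higher numbers for higher solubility), the higher of the two numbers measured so far; compound 1 `Cc1cc(-c2ccc3ccc(C(=O)c4ccc(F)c(O)c4)nc3c2)ccc1O` gives 13000 nM, and the step from compound 1 to compound 3 is a 1.9-fold higher number from compound 1 to compound 3 (0.28 log units; within the scatter), with cyano in place of 4-hydroxy-3-methylphenyl on an aromatic carbon. Compound 2 `CN(c1ccc(F)c(O)c1)c1cccc(-c2cccc(O)c2F)n1` gives > 200000 nM, which is a limit of this assay and not a number (the limit of > 200000 nM in this assay, at which 1 of the 3 values shown sits).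

Compound 4 `O=C(O)CNc1ccc2ccc(C(=O)c3ccc(F)c(O)c3)nc2c1` is the next member, not yet measured. It differs from compound 3 by (carboxymethyl)amino in place of cyano on an aromatic carbon. For the measured compounds named here, the only measured single step replaced a cyano with a different group and stayed within the scatter; no measured step introduces (carboxymethyl)amino anywhere, so nothing measured bears directly on this change. The number for compound 4 is therefore expected at 80000 nM, with a range from 25000 nM to 200000 nM. The expected step from compound 3 to compound 4 is a 3.2-fold higher number from compound 3 to compound 4 (0.51 log units; beyond the scatter), an estimate only, with a real chance that this assay returns a limit rather than a number.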

Compound 4, solubility: > 200000 nM
Compound 4 ended at the assay's limit; the forecaster's own chance of this, stated with the estimate: 30%; at least 2.5-fold (0.39 log units) between middle value and limit.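

In this assay, putting (carboxymethyl)amino in place of cyano gives an at least 8.0-fold higher number from compound 3 to compound 4 (0.90 log units; beyond the scatter), and putting it in place of 4-hydroxy-3-methylphenyl gives an at least 15-fold higher number from compound 1 to compound 4 (1.18 log units; beyond the scatter). Among the compounds shown here, the earlier change at this aromatic carbon of the shared core stayed within the scatter, so these are the first steps at this position to lie beyond it. Compound 4 stands at a limit of the assay and not at a number, and both steps give only a minimum size: the limit of > 200000 nM in this assay, at which 2 of the 4 values shown sit.

The compounds shown leave open which part of (carboxymethyl)amino accounts for the steps, since a plain amine or a methyl ester on the same aromatic carbon would separate the nitrogen from the carboxylic acid. On these data alone, whether a longer chain ending in a carboxylic acid gives the same result also remains open.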